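This account rests on a few compounds, and the source may have more. Where it says the series, first, only, none or still open, it means among the compounds named here.

Compound 1 `Cc1cc(CN2CCN(c3c(Cl)cnc4[nH]c(-c5ccn(C)n5)nc34)CC2)no1` gives 2600 nM
Compound 2 `CCn1cc(-c2nc3c(N4CCN(Cc5cc(C)on5)CC4)c(Cl)cnc3[nH]2)cn1` gives 2180 nM

In a functional assay on SW-620 cells (Homo sapiens) for inhibition, read by MTT assay, with a stated time of 72 h (on this read-out lower numbers stand for stronger inhibition of growth and higher numbers for weaker inhibition of growth), compound 2 gives 2180 nM and stands level, within the scatter, with compound 1 (2600 nM). Compound 3 `Cc1cc(CN2CCN(c3c(Cl)cnc4[nH]c(-c5ccoc5)nc34)CC2)no1` carries furan-3-yl in place of 1-ethyl-1H-pyrazol-4-yl on an aromatic carbon. Among the measured compounds shown here, the only measured exchange on this carbon (a 1.2-fold lower number from compound 1 to compound 2 (0.08 log units; within the scatter)) stayed within the scatter, so no step beyond the scatter is expected, although no furan-3-yl compound has been measured. The expected step is small (a 1.1-fold higher number from compound 2 to compound 3 (0.06 log units; within the scatter)). Compound 3 is estimated at 2500 nM (range 1000 nM to 6000 nM).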

Compound 3, concentration for 50% growth inhibition: 6500 nM
The estimate for compound 3 lay 2.6-fold (0.41 log units) below the measured number; the whole stated range lies below it.
By their numbers in this assay, from the lowest: compounds 2 and 1 (each within the scatter of the next); then compound 3.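

On the aromatic carbon between two ring nitrogen atoms, the exchange is no longer neutral in this assay: furan-3-yl gives a 3.0-fold higher number from compound 2 to compound 3 (0.47 log units; beyond the scatter) and a 2.5-fold higher number from compound 1 to compound 3 (0.40 log units; beyond the scatter), both modest, whereas 1-ethyl-1H-pyrazol-4-yl and 1-methyl-1H-pyrazol-3-yl stayed level within the scatter. The two pyrazole groups therefore sit together on the lower side, with the furan-3-yl group alone on the higher side. Nothing available accounts for this difference. Still open, from the compounds shown here alone, is whether an unsubstituted pyrazole, a thiophene or a phenyl ring on this carbon would stand with the pyrazole compounds or with compound 3.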